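Extending the Amide Chain on a Bicyclic Diamine

The compounds below may be only part of what the source reports. "The series", "measured", "known", "first", "only" and "open" are said of these compounds alone.

Compound 1 `CCC(=O)N1CC2CC(C1)N2` gives 180 nM in an assay on CHO cells for agonist activity at Neuronal acetylcholine receptor; alpha3/alpha6/beta2/beta3 (Homo sapiens), read by FLIPR and calcium flux; on this read-out lower numbers stand for an effect already at smaller amounts and higher numbers for an effect only at larger amounts of compound.
Compound 2 `CC(C)C(=O)N1CC2CC(C1)N2` gives 16000 nM in this assay.
Compound 3 `O=C(C1CCC1)N1CC2CC(C1)N2` gives 370 nM in this assay.

All three share one core and differ only in the group attached to the carbonyl. Compound 1 has the lowest number of the three. The nearest step is a 2.1-fold higher number from compound 1 to compound 3 (0.31 log units; beyond the scatter), a modest rise; the furthest is an 89-fold higher number from compound 1 to compound 2 (1.95 log units; beyond the scatter), a large one.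

Compound 4 `O=C(CC1C=CCC1)N1CC2CC(C1)N2` is the unmeasured candidate. Its change from compound 1 is cyclopent-2-en-1-yl in place of methyl on a saturated chain carbon bound to a carbonyl carbon. Going by the values given here, two measured steps bear on it. In compound 2 a methyl entered in place of hydrogen on the chain carbon bound to the carbonyl, and the number rose sharply. In compound 3 a cyclobutyl sat directly on the carbonyl, and the number rose only modestly. Compound 4 replaces the existing methyl rather than a hydrogen, so the chain carbon keeps its hydrogens, while a five-membered ring appears further along the chain. A modest rise is therefore expected in this assay, roughly a 2.8-fold higher number from compound 1 to compound 4 (0.44 log units; beyond the scatter), though the step from compound 1 to compound 2 leaves room for a larger loss. Compound 4 is estimated at 500 nM, within 120 nM to 2500 nM.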

Compound 4, half-maximal effective concentration: 21000 nM
The estimate for compound 4 lay 42-fold (1.62 log units) below the measured number, outside the stated range (above it).
By their numbers in this assay, from the lowest: compound 1; then compound 3; then compounds 2 and 4 (each within the scatter of the next).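

In this assay, the step of a 120-fold higher number from compound 1 to compound 4 (2.07 log units; beyond the scatter) shows that this position tolerates far less than compound 3 suggested, even though the chain carbon bound to the carbonyl carbon keeps its hydrogens in compound 4. Until now, the one large rise, an 89-fold higher number from compound 1 to compound 2 (1.95 log units; beyond the scatter), came with a methyl in place of a hydrogen on that carbon, so the loss could have seemed tied to that particular change; compound 4 shows that a large rise also comes from changing the group further along the chain, where cyclopent-2-en-1-yl, with 5 heavy atoms, replaces a methyl with 1. No measurement shown here explains why the number climbs so steeply.

The compounds shown jump directly from a methyl to a ring at this place, so it remains open whether an ethyl or a cyclopropyl there would keep the number close to that of compound 1. Going by these compounds, it is also open whether a saturated cyclopentyl would behave like cyclopent-2-en-1-yl, which would show whether the double bond matters to this loss.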